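A few compounds are considered here, and "the series" means these few. Any claim that something is new, unique, unknown or untested is made for them only; others in the source may bear on it.

Compound 2 `CCOC(=O)c1c(-c2ccc(OC)cc2)[nH]c2cccc(OC)c2c1=O` gives > 100000 nM in a physicochemical assay for solubility, in phosphate buffer, at pH 7.4 (a higher number here means a more soluble compound, a lower number a less soluble compound), and that value is a limit, not a number. Compound 1 `CCOC(=O)c1c(-c2ccc(C(F)(F)F)cc2)[nH]c2cccc(OC)c2c1=O` gives 22000 nM in this assay as a measured number. Compound 3 `CCOC(=O)c1c(-c2ccc(Cl)cc2)[nH]c2cccc(OC)c2c1=O` carries chloro in place of methoxy on an aromatic carbon, para to a large group; its difference from compound 2 is chloro in place of methoxy on an aromatic carbon and the change reads 4-methoxyphenyl to 4-chlorophenyl. Among the measured compounds shown here, the one measured step at this place, methoxy in place of trifluoromethyl, is an at least 4.5-fold higher number from compound 1 to compound 2 (0.65 log units; beyond the scatter) and on that evidence a step down in this assay beyond the scatter is expected when methoxy leaves. For the measured compounds named here, the true size of that measured step stays open, and no chloro compound has a reading yet. The estimate amounts to an expected at least 2.8-fold lower number from compound 2 to compound 3 (0.45 log units; beyond the scatter) and the starting point of that step is a limit. Compound 3 is estimated at 35000 nM with an expected range from 12000 nM to 100000 nM as a working figure.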

Compound 3, solubility: > 100000 nM
Compound 3 gave a limit, no number; the forecaster's own chance of this, stated with the estimate: 15%; at least 2.8-fold (0.45 log units) between middle value and limit.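

In this assay compound 3 gives > 100000 nM, a limit and not a number. Chloro in place of trifluoromethyl on the aromatic carbon gives an at least 4.5-fold higher number from compound 1 to compound 3 (0.65 log units; beyond the scatter), so two different groups at this position now read clear of compound 1, and among the three compounds trifluoromethyl alone carries a measured number. The step between compound 2 and compound 3 cannot be read, because both compounds sit at the same ceiling: the limit of > 100000 nM in this assay, at which 2 of the 3 values shown sit.

As far as these compounds go, how far methoxy and chloro differ stays open, as does the true size of the two steps away from compound 1. Also open, from the compounds shown here alone, is whether an amine, a carboxylic acid or a longer chain at this position would stay at that limit or fall to a measurable number.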